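The source may report more compounds than this note shows. Statements on the series, on what has been measured and on what is new or still open speak of the compounds shown alone.

In a functional assay on the whole organism with Canis familiaris (Canis lupus familiaris) as the target (a lower number here means that less compound is needed, a higher number that more compound is needed for the effect), compound 2 `OC(CSc1[nH]cnc2ncnc1-2)CN1CCN(C(c2ccc(Cl)cc2)c2ccc(Cl)cc2)CC1` gives 0.33 mg/kg and compound 1 `OC(CSc1[nH]cnc2ncnc1-2)CN1CCN(C(c2ccccc2)c2ccccc2)CC1` gives 0.63 mg/kg, two numbers within the usual scatter of each other. Compound 3 `OC(CSc1[nH]cnc2ncnc1-2)CN1CCN(C(c2ccccc2)c2ccc(Cl)cc2)CC1` has not yet been measured. It differs from compound 2 by hydrogen in place of chloro on an aromatic carbon. Within the data shown here, no measured pair shows this single change alone, but with compound 1 at 0.63 mg/kg the expectation in this assay is no step beyond the scatter. The expected step is a 1.4-fold higher number from compound 2 to compound 3 (0.13 log units; within the scatter). The estimate for compound 3 is 0.45 mg/kg, with an expected range of 0.22 mg/kg to 0.9 mg/kg.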

Compound 3, dose for half-maximal effect: 0.49 mg/kg
Compound 3: the middle estimate sits 1.1-fold (0.04 log units) below what was measured; the range from low to high includes it.
By their numbers in this assay, from the lowest: compounds 2, 3 and 1 (each within the scatter of the next).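

Taking one chloro away, a step of a 1.5-fold higher number from compound 2 to compound 3 (0.17 log units; within the scatter), and putting one onto the other side, a step of a 1.3-fold lower number from compound 1 to compound 3 (0.11 log units; within the scatter), are the first single-place comparisons at this position. In this assay, neither swap of hydrogen and chloro on an aromatic carbon can be told from the usual scatter, so these compounds show no measurable effect of this change in either direction. No supporting data here bear on this result. Still open, as far as these compounds go, is whether a different group at this position, such as methoxy or an amine, would give a step beyond the scatter.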